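Methoxy for Fluoro at a Cytotoxicity Limit

The source may hold more compounds than are shown below. What is called first, only, known or untested is meant among the compounds shown, and "the series" means these compounds.

Compound 3 `CN1CCN(c2nc(Oc3ccc(C#N)cn3)nc(-c3ccc(N4C(=O)CSC4c4ccc(F)cc4)cc3)n2)CC1` was tested in an ADME assay on Vero cells (Chlorocebus sabaeus) for cytotoxicity, read by MTT assay, with a stated time of 72 h; a lower number here means a stronger inhibitor, a higher number a weaker inhibitor. In this assay compound 3 reaches only the limit > 62.5 ug/mL, so no number is known for it. Compound 1 `COc1ccc(C2SCC(=O)N2c2ccc(-c3nc(Oc4ccc(C#N)cc4)nc(N4CCN(C)CC4)n3)cc2)cc1` likewise gives in this assay the limit > 62.5 ug/mL. Compound 2 `CN1CCN(c2nc(Oc3ccc(C#N)cn3)nc(-c3ccc(N4C(=O)CSC4c4ccc(Cl)cc4)cc3)n2)CC1` has no result in this assay: "not determined" (no result reported). For the measured compounds named here, of the values shown, (the limit of > 62.5 ug/mL in this assay, at which 2 of the 3 values shown sit); compound 3 thus stands at the limit itself, and no step between measured compounds is available to judge the size of a change. Compound 4 `COc1ccc(C2SCC(=O)N2c2ccc(-c3nc(Oc4ccc(C#N)cn4)nc(N4CCN(C)CC4)n3)cc2)cc1` differs from compound 3 by methoxy in place of fluoro on an aromatic carbon. Going by the values given here, compound 1 carries the same 4-methoxyphenyl as compound 4 and sits at the limit, which is the only guide present. In this assay the expected step is a step that the limit leaves unreadable from compound 3 to compound 4, none beyond the scatter. Compound 4 is therefore expected to give 100 ug/mL in this assay, between 50 ug/mL and 200 ug/mL, most likely reported again only as a limit.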

Compound 4, half-maximal inhibitory concentration: > 62.5 ug/mL
Compound 4 was reported as a limit; the forecaster's own chance of this, stated with the estimate: 80%; the middle value is on the limit's open side.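

Compound 1, compound 3 and compound 4 are all reported only as limits, so no new step can be read between compound 3 and compound 4 or between compound 1 and compound 4: the limit of > 62.5 ug/mL in this assay, at which 3 of the 4 values shown sit. The compounds shown leave open how far beyond that limit each lies in this assay, and whether either methoxy for fluoro or 5-cyanopyridin-2-yl for 4-cyanophenyl changes the result at all.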